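This account rests on a few compounds, and the source may have more. Where it says the series, first, only, none or still open, it means among the compounds named here.

Compound 1, `COc1ccc2c(c1)OC(c1cc(OC)c(OC)c(OC)c1)C(C(=O)N(C)OC)=C2`, gives 11700 nM in a functional assay for inhibition of nuclear factor NF-kappa-B complex (Homo sapiens); a lower number here means a stronger inhibitor, a higher number a weaker inhibitor. Compound 2, `CCOCC1=Cc2ccc(OC)cc2OC1c1cc(OC)c(OC)c(OC)c1`, gives 21300 nM. Compound 3, `COc1ccc2c(c1)OC(c1cc(OC)c(OC)c(OC)c1)C(C(=O)NC(C)C)=C2`, reaches only a limit of the assay, > 50000 nM.

Compound 2 stands at the top of the two plain numbers, but the step of a 1.8-fold higher number from compound 1 to compound 2 (0.26 log units; within the scatter) lies within the scatter, so it is not separated from compound 1. Compound 4, `CNC(=O)C1=Cc2ccc(OC)cc2OC1c1cc(OC)c(OC)c(OC)c1`, differs from compound 2 by methylcarbamoyl in place of ethoxymethyl on a double-bonded ring carbon. The most relevant measured step also swapped the ethoxymethyl for a carbamoyl: an at least 2.3-fold higher number from compound 2 to compound 3 (0.37 log units; beyond the scatter). A carbamoyl there seems to weaken inhibition, although compound 1 with its methoxy(methyl)carbamoyl is barely different from compound 2. For compound 4 a modest rise is expected, a 1.4-fold higher number from compound 2 to compound 4 (0.15 log units; within the scatter), with an estimated 30000 nM in a range from 12000 nM to 70000 nM.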

Compound 4, half-maximal inhibitory concentration: > 50000 nM
Compound 4 gave a limit, no number; the forecaster's own chance of this, stated with the estimate: 35%; middle value at least 1.6-fold (0.22 log units) from the limit.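

Putting methylcarbamoyl in place of ethoxymethyl weakens inhibition, with an at least 2.3-fold higher number from compound 2 to compound 4 (0.37 log units; beyond the scatter). Within the data shown here, on the amide-type nitrogen, hydrogen in place of methoxy also weakens it, with an at least 4.2-fold higher number from compound 1 to compound 4 (0.63 log units; beyond the scatter), so the amide in compound 1 gives a number where the one in compound 4 gives only a limit. Compound 3 and compound 4, the two compounds with an amide hydrogen, both sit at a limit, so the step between them cannot be read: the limit of > 50000 nM in this assay, at which 2 of the 4 values shown sit.

Going by these compounds, how far either compound lies past that limit stays open. Also open, on these data alone, is whether a carboxylic acid or an amine on this ring carbon would give a number.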